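Swapping tert-butyl for methylsulfanyl in a weakly cytotoxic series

The compounds below may be only part of what the source reports. "The series", "measured", "known", "first", "only" and "open" are said of these compounds alone.

Of the compounds shown here, two with a shared core have been tested in an ADME assay on Raji cells (Homo sapiens) for cytotoxicity, with a stated time of 72 h (a lower number here means that less compound is needed, a higher number that more compound is needed for the effect), and neither shows much effect on the cells. Compound 1 `Cc1cc(NC(=O)Nc2ccc(C(C)(C)C)cc2)c2ccccc2n1` gives no number, only a limit of the assay, > 25000 nM. Compound 2 `Cc1cc(NC(=O)Nc2ccc(Cl)c(Cl)c2)c2ccccc2n1` does give a number, 10000 nM. Compound 1 therefore stands at the top of the tested range, with its true value unknown.

Compound 3 `CSc1ccc(NC(=O)Nc2cc(C)nc3ccccc23)cc1` has not yet been measured. It comes from compound 1 by one change, methylsulfanyl in place of tert-butyl on an aromatic carbon, para to a large group (methylsulfanyl in place of tert-butyl on an aromatic carbon). Among the measured compounds shown here, no step between measured compounds is available as a guide, so the expectation is tentative. Compound 2, at 10000 nM, shows that a different substitution on the shared core can return a number in this assay. A modest move towards a lower number is therefore expected, and another reading at the limit remains possible. The expected step is an at least 1.9-fold lower number from compound 1 to compound 3 (0.28 log units; that floor lies within the scatter). For compound 3 the estimated value is 13000 nM, with an expected range from 6000 nM to 25000 nM.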

Compound 3, half-maximal effective concentration: > 25000 nM
Compound 3: no number, only a limit; the forecaster's own chance of this, stated with the estimate: 35%; middle value at least 1.9-fold (0.28 log units) away from the limit.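

In this assay compound 3 gives > 25000 nM as a limit of the assay and not a number. Among the compounds shown here, compound 1 stands at a limit too, so no step between compound 1 and compound 3 can be read: the limit of > 25000 nM in this assay, at which 2 of the 3 values shown sit. The compounds shown leave open where the true values of both lie, and whether methylsulfanyl in place of tert-butyl changes the reading at all.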